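The source may hold more compounds than are shown below. What is called first, only, known or untested is meant among the compounds shown, and "the series" means these compounds.

Three compounds share one core and differ only in the side group attached to it. Compound 1 `Nc1cc(N)c2nc(-c3ccccc3)c(Oc3ccc(Cl)c(Cl)c3)nc2c1` carries a 3,4-dichlorophenoxy group on that core. Compound 2 `Nc1cc(N)c2nc(-c3ccccc3)c(NCc3ccc(Cl)c(Cl)c3)nc2c1` keeps the same dichlorinated ring but joins it through a nitrogen-linked chain instead of an oxygen. Compound 3 `CCOC(=O)[C@H](CCC(=O)O)NC(=O)c1ccc(Sc2nc3cc(N)cc(N)c3nc2-c2ccccc2)cc1` carries a much larger sulfur-linked side chain ending in an ester and a free acid.

In a functional assay on RPMI8266 cells (Homo sapiens) for inhibition, read by sulforhodamine B assay, with a stated time of 48 h (on this read-out higher numbers stand for weaker inhibition of growth and lower numbers for stronger inhibition of growth), compound 1 gives 3470 nM, the highest number of the three, which here means the weakest growth inhibition. Compound 2 gives 1660 nM, a lower number by a margin beyond the usual scatter. Compound 3 gives 339 nM, lower still and again beyond the scatter. Compound 1 therefore stands as the weakest inhibitor among the measured compounds.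

Compound 4 `Nc1cc(N)c2nc(-c3ccccc3)c(Oc3ccc(F)cc3)nc2c1` has not yet been measured. It differs from compound 1 in a single place: 4-fluorophenyl in place of 3,4-dichlorophenyl on an oxygen on an aromatic ring. Among the compounds with values here, none of the measured compounds show this exact change, so its effect has not been observed directly. The step of a 1.4-fold higher number from compound 1 to compound 4 (0.16 log units; within the scatter) is expected to be small, leaning toward a slightly higher number, and may well lie within the scatter. Compound 4 is accordingly estimated at 5000 nM in this assay, with a range from 1500 nM to 16000 nM.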

Compound 4, concentration for 50% growth inhibition: 12300 nM
Compound 4: middle estimate off by 2.5-fold (0.39 log units), on the low side, and the stated range covers the measured number.
By their numbers in this assay, from the lowest: compound 3; then compound 2; then compound 1; then compound 4.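

Replacing 3,4-dichlorophenyl with 4-fluorophenyl leaves the shared core and the linking oxygen untouched, so this pair isolates the ring at the end of the side group. In this assay that single replacement gives a 3.5-fold higher number from compound 1 to compound 4 (0.55 log units; beyond the scatter) and therefore weaker growth inhibition, which shows that the activity of this series depends on what this outer ring carries, and that, of these two rings, 3,4-dichlorophenyl gives the stronger inhibition. No measurement shown here explains why this replacement weakens growth inhibition.

The replacement also changes more than one feature of the ring at once: two chlorines leave and one fluorine enters, so the pair cannot separate the loss of the 3-chloro group from the exchange of chlorine for fluorine at the 4-position. Rings such as 4-chlorophenyl, 3-chlorophenyl and plain phenyl on the same oxygen would pull these contributions apart, while a 3,4-difluorophenyl ring would test whether keeping both halogen positions but using fluorine is enough to hold the activity of compound 1.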